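Removing the Methyl From Compound 1

The source may hold more compounds than are shown below. What is called first, only, known or untested is meant among the compounds shown, and "the series" means these compounds.

Compound 1 `Cc1ccc2cnc(-c3cccc(C#N)c3)nc2n1`: 240 nM
Compound 2 `COc1cc(C#N)cc(-c2ncc3ccc(C)nc3n2)c1`: 1.2 nM

Among the measured compounds shown here, in a functional assay on CHO cells for antagonist activity at metabotropic glutamate receptor 5 (Rattus norvegicus), read by FLIPR and calcium flux (a lower number here means a stronger inhibitor, a higher number a weaker inhibitor), compound 1 gives 240 nM, the higher of the two numbers, while compound 2 gives 1.2 nM; the only measured step is a 200-fold lower number from compound 1 to compound 2 (2.30 log units; beyond the scatter). Compound 3 `N#Cc1cccc(-c2ncc3cccnc3n2)c1` differs from compound 1 by hydrogen in place of methyl on an aromatic carbon. For the measured compounds named here, no measured step bears on this change, since the single step concerns a methoxy group at another position and says nothing about the methyl. With nothing to guide it, the expectation for compound 3 is a step of a 1.7-fold higher number from compound 1 to compound 3 (0.22 log units; within the scatter), within the scatter. Compound 3 is therefore expected near 400 nM, within 150 nM to 1200 nM.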

Compound 3, half-maximal inhibitory concentration: > 26100 nM
Compound 3 gave a limit, no number (the forecaster's own chance of this, stated with the estimate: 5%); at least 65-fold (1.81 log units) between middle value and limit.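

In this assay, replacing the methyl next to the ring nitrogen with hydrogen gives an at least 100-fold higher number from compound 1 to compound 3 (2.03 log units; beyond the scatter), so a single carbon at this position decides much of the inhibition seen with this core. The value for compound 3 is a limit, not a number: the limit of > 26100 nM in this assay, at which 1 of the 3 values shown sits. Among the compounds shown here, the earlier step concerned a methoxy group at another position, and only this change shows how much depends on the methyl.

The compounds shown carry only methyl or hydrogen here, so whether an ethyl group, a chlorine or an amine would serve stays open. Also open, on these data alone, is whether compound 2 would lose as much without its methyl.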